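The source may hold more compounds than are shown below. What is called first, only, known or untested is meant among the compounds shown, and "the series" means these compounds.

Notes on the series. Compound 1 `N#Cc1cc(C#N)cc(-n2nnc(-c3ccccn3)n2)c1` gives 34 nM in a functional assay with metabotropic glutamate receptor 5 (Rattus norvegicus) as the target; a higher number here means a weaker inhibitor, a lower number a stronger inhibitor. Compound 2 `COc1cc(C#N)cc(-n2nnc(-c3ccccn3)n2)c1` gives 10 nM in this assay. Within the data shown here, the one measured step, a 3.4-fold lower number from compound 1 to compound 2 (0.53 log units; beyond the scatter), is a methoxy in place of a cyano on an aromatic carbon. On the two numbers at hand, compound 2 stands lowest, with compound 1 the nearest at the distance just given.

Compound 3 `N#Cc1cc(Oc2cccnc2)cc(-n2nnc(-c3ccccn3)n2)c1` is the next member. The change from compound 2 is pyridin-3-yl in place of methyl on an oxygen on an aromatic ring; cut one bond further out it reads methoxy to (pyridin-3-yl)oxy. Among the measured compounds shown here, no measured step bears directly on this: the only step known, from compound 1 to compound 2, exchanges the group on the aromatic carbon itself, whereas here the oxygen is kept and only what sits on it grows. That step was modest in size, and a move of comparable size in either direction, or none beyond the scatter, is the working assumption.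

Compound 3 is therefore expected to land near compound 2, with an estimated step of a 1.4-fold higher number from compound 2 to compound 3 (0.15 log units; within the scatter) and a value of 14 nM, the range running from 4 nM to 60 nM.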

Compound 3, half-maximal inhibitory concentration: 15 nM
For compound 3 the middle estimate is 1.1-fold (0.03 log units) below the measured one; low and high end bracket the measured number.
By their numbers in this assay, from the lowest: compounds 2 and 3 (each within the scatter of the next); then compound 1.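

In this assay the methyl on the oxygen on the aromatic ring gives way to the far larger pyridin-3-yl with a 1.5-fold higher number from compound 2 to compound 3 (0.18 log units; within the scatter) as the whole step, so compounds 2 and 3 cannot be told apart and this position accepts an aromatic ring on the oxygen as readily as a methyl. Set against the cyano group of compound 1, the (pyridin-3-yl)oxy group gives a 2.3-fold lower number from compound 1 to compound 3 (0.36 log units; beyond the scatter) as its step, which places both oxygen-linked compounds on the lower side of the nitrile; among the three compounds none goes against this. Nothing measured alongside these numbers offers an explanation for either step.

As far as these compounds go, with a single aromatic group on this oxygen, it remains open whether a plain phenyl would fall in the same range and so whether the ring nitrogen of the pyridin-3-yl matters at all. Also open, from the compounds shown here alone, are a longer chain such as butyl on the oxygen, an amine or a carboxylic acid carried on the new ring, and a direct carbon link in place of the oxygen.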